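Swapping the aryl group on the core of compound 2

A few compounds are considered here, and "the series" means these few. Any claim that something is new, unique, unknown or untested is made for them only; others in the source may bear on it.

Values in a functional assay on MCF7 cells (Homo sapiens) for cytotoxicity, read by MTT assay, with a stated time of 96 h (a lower number here means a stronger inhibitor, a higher number a weaker inhibitor), so far
- compound 1 `COc1cc(C(=O)c2cn(-c3ccccc3[N+](=O)[O-])cc2-c2ccccc2)cc(OC)c1OC` gives 5000 nM
- compound 2 `COc1cc(C(=O)c2cn(-c3ccccc3)cc2-c2cccc(Cl)c2)cc(OC)c1OC` gives 540 nM

Compound 2 holds the lower of the two numbers, and its gap to compound 1 lies beyond the scatter. The two compounds differ in more than one place, so that gap cannot be assigned to any single group. Compound 3 `COc1ccccc1-c1cn(-c2ccccc2)cc1C(=O)c1cc(OC)c(OC)c(OC)c1` is still unmeasured. It carries 2-methoxyphenyl in place of 3-chlorophenyl on an aromatic carbon and otherwise matches compound 2. For the measured compounds named here, no measured pair isolates this change, so the data give no size for it. In this assay no shift beyond the scatter is expected, and the estimated step of a 1.4-fold lower number from compound 2 to compound 3 (0.13 log units; within the scatter) rests only on compound 2 at 540 nM as the closest reference. Compound 3 is estimated at 400 nM with an expected range of 80 nM to 2000 nM in this measurement.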

Compound 3, half-maximal inhibitory concentration: 190 nM
For compound 3 the middle estimate is 2.1-fold (0.32 log units) above the measured one, within the range that was stated.
By their numbers in this assay, from the lowest: compound 3; then compound 2; then compound 1.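

For the compounds shown here, this pair gives the first size for a change at this position, the aromatic carbon two ring bonds from the ring nitrogen: in this assay, 2-methoxyphenyl in place of 3-chlorophenyl gives a 2.8-fold lower number from compound 2 to compound 3 (0.45 log units; beyond the scatter), so the number here depends on the aryl group carried at this position. Chlorine leaves and a methoxy oxygen enters in the same step, and the substituent also sits elsewhere on the phenyl ring, so the step belongs to the swap as a whole and not to any one of these features. No measurement at hand accounts for the step.

The compounds shown include no pair that differs only in the methoxy group. Going by these compounds alone, they include no pair that differs only in the chlorine either. They also leave open how a longer alkoxy chain, an amine or a carboxylic acid on this aryl ring would read out.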